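This account rests on a few compounds, and the source may have more. Where it says the series, first, only, none or still open, it means among the compounds named here.

Measured compounds:
- Compound 1, `O=C(c1cc2ccccc2o1)N1CCC(NCCSC(c2ccc(F)cc2)c2ccc(F)cc2)CC1`, gives 115 nM in an assay on membranes from striatum (strain Sprague-Dawley) for displacement of a labelled ligand from sodium-dependent dopamine transporter (Rattus norvegicus), read by scintillation counting, with a stated time of 120 min; a higher number here means a weaker inhibitor, a lower number a stronger inhibitor.
- Compound 2, `CC(C)(C)C(=O)N1CCC(NCCSC(c2ccc(F)cc2)c2ccc(F)cc2)CC1`, gives 352 nM in this assay.

Among the measured compounds shown here, compound 2 stands highest of the two numbers measured so far; its nearest neighbour is compound 1, and the step of a 3.1-fold higher number from compound 1 to compound 2 (0.49 log units; beyond the scatter) carries it there. The unmeasured compound 3, `O=C(c1ccc(F)cc1F)N1CCC(NCCSC(c2ccc(F)cc2)c2ccc(F)cc2)CC1`, differs from compound 2 in one place: 2,4-difluorophenyl in place of tert-butyl on a carbonyl carbon.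

For the measured compounds named here, only one measured step bears on this change. It replaced an aromatic group on the carbonyl carbon with tert-butyl, and the number rose by a 3.1-fold higher number from compound 1 to compound 2 (0.49 log units; beyond the scatter), a modest step beyond the scatter. Compound 3 goes the other way, putting an aromatic ring back on the carbonyl carbon, though a different one from that of compound 1. A modest step back down is therefore expected for compound 3, likely a 2.1-fold lower number from compound 2 to compound 3 (0.32 log units; beyond the scatter), landing between the two measured values or close to compound 1. The estimate for compound 3 in this assay is 170 nM, with a range from 70 nM to 420 nM.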

Compound 3, inhibition constant: 30 nM
Compound 3: middle estimate off by 5.7-fold (0.75 log units), on the high side, and the stated range ends above it.
By their numbers in this assay, from the lowest: compound 3; then compound 1; then compound 2.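

On the carbonyl carbon whose other neighbour is the amide-type nitrogen in a ring, this assay shows a much larger response than the first step suggested: 2,4-difluorophenyl in place of tert-butyl gives a 12-fold lower number from compound 2 to compound 3 (1.07 log units; beyond the scatter) as a large step. The identity of the aromatic group also matters, not merely its presence, since 2,4-difluorophenyl in place of 1-benzofuran-2-yl gives a 3.8-fold lower number from compound 1 to compound 3 (0.58 log units; beyond the scatter) as a modest step beyond the scatter, and among these three compounds the order runs 2,4-difluorophenyl, then 1-benzofuran-2-yl, then tert-butyl. Nothing available explains why this group gives the lowest number of the three.

The compounds shown leave open whether the two fluorines contribute at all, a question that a plain phenyl or a 4-fluorophenyl on the same carbonyl would address. They also leave open whether an aromatic ring is needed here, which a cyclohexyl in the same place, set against both tert-butyl and 2,4-difluorophenyl, would begin to answer.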